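From Fluoro to Methoxy: Estimating an Unmeasured Analogue

The compounds below may be only part of what the source reports. "The series", "measured", "known", "first", "only" and "open" are said of these compounds alone.

Measured so far in a functional assay on HCT-15 cells (Homo sapiens) for cytotoxicity, read by MTT assay, with a stated time of 2 days; a higher number here means a weaker inhibitor, a lower number a stronger inhibitor:
- compound 1, `O=c1[nH]c(-c2cccc3ccccc23)nc2ccc(N3CCCCC3)cc12`, gives 2240 nM.
- compound 2, `Cc1ccc2nc(-c3cccc(F)c3)[nH]c(=O)c2c1`, gives only a limit, > 50000 nM.
- compound 3, `Cc1ccc2nc(-c3ccccc3OC(F)(F)F)[nH]c(=O)c2c1`, gives 2790 nM.

Among the compounds with values here, compound 2 therefore stands at the edge of what this assay can report: its result is a limit, not a number, and it is the one value among the three that sits at the limit of > 50000 nM in this assay, at which 1 of the 3 values shown sits. Compound 1 and compound 3 each give a measured number and are within the usual scatter of one another, so no order between them can be claimed.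

The new compound, compound 4, `COc1cccc(-c2nc3ccc(C)cc3c(=O)[nH]2)c1`, is built from compound 2 by a single change: methoxy in place of fluoro on an aromatic carbon.

Within the data shown here, no measured pair in this set shows what this exchange does, and with compound 2 known only as a limit, the step from it to compound 4 cannot be read off directly. The step expected from the change is an at least 2.5-fold lower number from compound 2 to compound 4 (0.39 log units; beyond the scatter), meaning a somewhat stronger inhibitor is expected, though with wide uncertainty, and a fair chance that this assay again returns only a limit. On that basis compound 4 is estimated at 20000 nM, in the range 4000 nM to 80000 nM.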

Compound 4, half-maximal inhibitory concentration: 32000 nM
The estimate for compound 4 lay 1.6-fold (0.20 log units) below the measured number; measured number inside the range.
By their numbers in this assay, from the lowest: compounds 1 and 3 (each within the scatter of the next); then compound 4. At a limit, above all of these: compound 2.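

In this assay compound 2 gives > 50000 nM, which is a limit of the assay and not a number. Compound 4 gives 32000 nM, so putting methoxy in place of fluoro on this aromatic carbon, meta to a large group, yields a measured value, and the change can be stated only as a floor: an at least 1.5-fold lower number from compound 2 to compound 4 (0.19 log units; that floor lies within the scatter). That floor is too small to prove a real gain in strength, and the true size of the step stays unknown, with the reason lying in where compound 2 stands: the limit of > 50000 nM in this assay, at which 1 of the 4 values shown sits.

Still open, from the compounds shown here alone, is what other groups on this same carbon would do in this assay, for example a nitrile, a carboxylic acid or a longer chain such as ethoxy, and whether any of them would give a lower number than compound 4. Also open, going by these compounds, is how large the exchange of fluoro for methoxy really is, a question that would need a pair of compounds that both give a measured number.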